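Chloro added to the phenyl of compound 3

This account rests on a few compounds, and the source may have more. Where it says the series, first, only, none or still open, it means among the compounds named here.

Compound 3 `O=C(O)c1csc(SCCN2C(=O)CC[C@@H]2/C=C/[C@@H](O)Cc2cccc(-c3ccccc3)c2)n1` gives 4200 nM in an assay on CHO cells for displacement of a labelled ligand from prostaglandin E2 receptor EP1 subtype (Mus musculus), read by scintillation counting, with a stated time of 20 min (on this read-out lower numbers stand for stronger inhibition and higher numbers for weaker inhibition), the lowest of the two numbers available; compound 1 `O=C(O)CCCSCCN1C(=O)CC[C@@H]1/C=C/[C@@H](O)Cc1cccc(N2Cc3ccccc3C2)c1` gives 7100 nM in this assay, a gap within the scatter. For compound 2 `O=C(O)CCCSCCN1C(=O)CC[C@@H]1/C=C/[C@@H](O)Cc1cccc(-c2nc3ccccc3s2)c1` only the assay limit > 10000 nM is available. For the measured compounds named here, the single measured step, an at least 1.4-fold higher number from compound 1 to compound 2 (0.14 log units; that floor lies within the scatter), concerns a different place on the shared core and sits at the floor (the limit of > 10000 nM in this assay, at which 1 of the 3 values shown sits), so it does not bear on the change at hand. Compound 4 `O=C(O)c1csc(SCCN2C(=O)CC[C@@H]2/C=C/[C@@H](O)Cc2cccc(-c3ccc(Cl)cc3)c2)n1` carries chloro in place of hydrogen on an aromatic carbon. Going by the values given here, no measured step tests that change; the expectation is therefore no step beyond the scatter, a 1.2-fold lower number from compound 3 to compound 4 (0.08 log units; within the scatter). Compound 4 is estimated at 3500 nM in this assay, with a range from 1200 nM to 10000 nM.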

Compound 4, inhibition constant: 6300 nM
Estimate against measurement, compound 4: 1.8-fold (0.26 log units) below; the range from low to high includes it.
By their numbers in this assay, from the lowest: compounds 3, 4 and 1 (each within the scatter of the next). At a limit, above all of these: compound 2.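

The change from phenyl to 4-chlorophenyl, para to a large group, now has a direct test: in this assay it gives a 1.5-fold higher number from compound 3 to compound 4 (0.18 log units; within the scatter). Chloro in place of hydrogen at this position therefore produces no shift beyond the scatter, and the position tolerates this one added atom without a clear loss or gain. No measurement shown gives a reason for this step.

As far as these compounds go, whether an amine, a methoxy or a nitrile at the same position would move the number remains open. So does the effect of chloro elsewhere on this ring.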